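Second chloro on the meta-substituted purine core

The source may report more compounds than this note shows. Statements on the series, on what has been measured and on what is new or still open speak of the compounds shown alone.

Three compounds share a core carrying a chloromethyl-substituted benzyl group. Compound 1 `ClCc1ccccc1Cn1cnc2c(Cl)nc(Cl)nc21` gives 1470 nM in a functional assay on BT-549 cells (Homo sapiens) for cytotoxicity, read by sulforhodamine B assay, with a stated time of 48 h; on this read-out higher numbers stand for weaker inhibition of growth and lower numbers for stronger inhibition of growth. Compound 2 `ClCc1cccc(Cn2cnc3ncnc(Cl)c32)c1` gives 28800 nM in this assay, and compound 3 `ClCc1cccc(Cn2cnc3c(Cl)ncnc32)c1` gives 30200 nM. Among these numbers compound 3 stands highest, though its value and that of compound 2 fall within the scatter of each other, so no order between the two can be claimed; compound 1 lies well beyond the scatter from compound 3 and inhibits growth far more strongly.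

Compound 4 `ClCc1cccc(Cn2cnc3c(Cl)nc(Cl)nc32)c1` has not been measured. It differs from compound 3 by chloro in place of hydrogen on an aromatic carbon. No direct comparison of this change within a single benzyl pattern exists among the measured compounds, and compound 1 differs from compound 3 in more than one place. The author nonetheless expects the step of a 3.0-fold lower number from compound 3 to compound 4 (0.48 log units; beyond the scatter) to go toward stronger growth inhibition, of modest size, because compound 1 gives 1470 nM and likewise carries two chloro groups. Compound 4 is therefore estimated at 10000 nM, within a range of 2000 nM to 40000 nM.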

Compound 4, concentration for total growth inhibition: 3230 nM
Estimate against measurement, compound 4: 3.1-fold (0.49 log units) above; the measured number falls inside the stated range.
By their numbers in this assay, from the lowest: compound 1; then compound 4; then compounds 2 and 3 (each within the scatter of the next).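

In this assay, chloro in place of hydrogen on the aromatic carbon between two ring nitrogen atoms gives a 9.3-fold lower number from compound 3 to compound 4 (0.97 log units; beyond the scatter) and moves toward stronger inhibition of growth. Within the data shown here, this is the only comparison that changes one place, and it shows that this position responds to the change: a single added chloro, meta to a chloro group, carries the number beyond the scatter. Nothing measured here explains the step.

Whether the step belongs to chloro in particular stays open, since no amine, methoxy group or fluoro stands at this position in the compounds shown. Also open, on these data alone, is whether the same change would give a step of similar size with the chloromethyl group placed as in compound 1.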